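The source may hold more compounds than are shown below. What is called first, only, known or untested is meant among the compounds shown, and "the series" means these compounds.

Measured in a functional assay on MCF7 cells (Homo sapiens) for antiproliferative activity; a higher number here means a weaker inhibitor, a lower number a stronger inhibitor:
- Compound 1 `CC(C)=CCc1cc(C(=O)Nc2cc3ccc(OCC4CCCN(C)C4)c(C)c3oc2=O)ccc1O`: 2640 nM
- Compound 2 `CCCNCCCOc1ccc2cc(NC(=O)c3ccc(O)c(CC=C(C)C)c3)c(=O)oc2c1C`: 980 nM

Compound 2, at 980 nM, holds the lower of the two numbers. Compound 3 `CC(C)=CCc1cc(C(=O)Nc2cc3ccc(OCCCNCC(C)C)c(C)c3oc2=O)ccc1O` differs from it as follows: methyl in place of hydrogen on a saturated chain carbon bound to two saturated chain carbons. This is methyl in place of hydrogen on a saturated chain carbon bound to two saturated chain carbons, turning propylamino into isobutylamino.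

For the measured compounds named here, only one measured step bears on this, and only loosely: a 2.7-fold lower number from compound 1 to compound 2 (0.43 log units; beyond the scatter). It put 2-(propylamino)ethyl in place of 1-methylpiperidin-3-yl, a larger change than the one at hand. Going by the values given here, no measured pair tests a single added methyl. No step beyond the scatter is therefore expected in this assay, and neither direction is favoured. The expected change is a 1.0-fold higher number from compound 2 to compound 3 (0.01 log units; within the scatter). Compound 3 is expected at 1000 nM, with an estimated range from 450 nM to 2300 nM.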

Compound 3, half-maximal inhibitory concentration: 1320 nM
For compound 3 the middle estimate is 1.3-fold (0.12 log units) below the measured one, and the stated range covers the measured number.
By their numbers in this assay, from the lowest: compounds 2, 3 and 1 (each within the scatter of the next, the first and the last beyond it).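

In this assay, for the compounds shown here, the methyl that turns propylamino into isobutylamino gives a 1.3-fold higher number from compound 2 to compound 3 (0.13 log units; within the scatter) and so provides the first direct reading of a single added methyl on this saturated chain carbon, a change that stays within the scatter. Measured against the 1-methylpiperidin-3-yl group of compound 1, the isobutylamino chain gives a 2.0-fold lower number from compound 1 to compound 3 (0.30 log units; within the scatter) while the propylamino chain gives a 2.7-fold lower number from compound 1 to compound 2 (0.43 log units; beyond the scatter) and only the latter lies beyond the scatter, though compound 2 and compound 3 remain within the scatter of each other. No measurement offered here accounts for either step.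

The compounds shown leave open whether a longer chain on the nitrogen, such as pentyl, would move the number beyond the scatter. They also leave open what a cyclopropylmethyl group or a carboxylic acid in place of the amine would do.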